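Extending the ether chain from compound 2 to compound 3

This account rests on a few compounds, and the source may have more. Where it says the series, first, only, none or still open, it means among the compounds named here.

In a functional assay, read by spectrophotometry, with a stated time of 6 min (on this read-out higher numbers stand for weaker inhibition and lower numbers for stronger inhibition), compound 1 `CCCCCCCCOc1cc(OC)c(Br)cc1C(C)=O` gives 32000000 nM as its half-maximal inhibitory concentration. Compound 2 `CCCCCCCCCCCCOc1cc(OC)c(Br)cc1C(C)=O` gives 32700000 nM in this assay and stands level with compound 1, within the scatter.

For the measured compounds named here, only one measured step bears on the next change. With butyl in place of hydrogen on a saturated chain carbon, eight bonds along the chain from an oxygen on an aromatic ring, the numbers show a 1.0-fold higher number from compound 1 to compound 2 (0.01 log units; within the scatter) and this lies within the scatter.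

Compound 3 `CCCCCCCCCCCCCCOc1cc(OC)c(Br)cc1C(C)=O` keeps the shared core and changes the chain again: ethyl in place of hydrogen on a saturated chain carbon, ten or more bonds along the chain from an oxygen on an aromatic ring is the difference. Going by the values given here, a single step cannot establish a trend, and no measurement yet covers a chain of this length.

From the flat step a 1.0-fold higher number from compound 1 to compound 2 (0.01 log units; within the scatter) no change beyond the scatter is expected in this assay, and the expected step is a 1.0-fold lower number from compound 2 to compound 3 (0.01 log units; within the scatter) in size. Compound 3 is estimated at 32000000 nM with 15000000 nM to 70000000 nM as the expected range.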

Compound 3, half-maximal inhibitory concentration: 8700000 nM
For compound 3 the middle estimate is 3.7-fold (0.57 log units) above the measured one, and the stated range ends above it.
By their numbers in this assay, from the lowest: compound 3; then compounds 1 and 2 (each within the scatter of the next).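

In this assay, for the compounds shown here, the chain at this position is no longer without effect: ethyl in place of hydrogen on a saturated chain carbon, ten or more bonds along the chain from an oxygen on an aromatic ring, gives the first step beyond the scatter (a 3.8-fold lower number from compound 2 to compound 3 (0.58 log units; beyond the scatter)), whereas the earlier butyl extension stayed within it (a 1.0-fold higher number from compound 1 to compound 2 (0.01 log units; within the scatter)). Taken over the whole length, hexyl in place of hydrogen gives a step of much the same size (a 3.7-fold lower number from compound 1 to compound 3 (0.57 log units; beyond the scatter)), so the stronger inhibition appears only with the last extension and does not build steadily along the chain, with compound 2 going against any even trend with length. No evidence on the origin of this change is available.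

Going by these compounds, whether the lower number persists, deepens or reverses with a longer chain than that of compound 3, or with a chain ending in a carboxylic acid or an amine, stays open. Among the compounds shown only the chain differs, so the contribution of the rest of the shared core also remains open.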